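Amide Substituent Swap on the Methoxy Chromone Core

The compounds below may be only part of what the source reports. "The series", "measured", "known", "first", "only" and "open" are said of these compounds alone.

Compound 1 `O=C(/C=C/c1coc2cc(O)ccc2c1=O)NCc1ccc(F)cc1` gives > 100000 nM in a functional assay on HeLa cells (Homo sapiens) for inhibition, read by MTT assay, with a stated time of 48 h (a higher number here means a weaker inhibitor, a lower number a stronger inhibitor), a limit rather than a number.
Compound 2 `COc1ccc2c(=O)c(/C=C/C(=O)Nc3cc(C)ccc3C)coc2c1` gives 58400 nM in this assay.
Compound 3 `Cc1ccccc1NC(=O)/C=C/c1coc2cc(O)ccc2c1=O` gives 8670 nM in this assay.

Among the two numbers shown, compound 2 stands highest, with compound 3 nearest at a lower value. Compound 4 `CCOc1ccc(NC(=O)/C=C/c2coc3cc(OC)ccc3c2=O)cc1` has not yet been measured in this assay. It differs from compound 2 in one place: 4-ethoxyphenyl in place of 2,5-dimethylphenyl on an amide-type nitrogen.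

Within the data shown here, the only measured step that touches the amide-type nitrogen is an at least 11-fold lower number from compound 1 to compound 3 (1.06 log units; beyond the scatter), and it began from compound 1 at a limit (the limit of > 100000 nM in this assay, at which 1 of the 3 values shown sits), so it sets only a loose bound and compares a benzyl-type group with an aryl one rather than two aryl groups. The change from compound 2 to compound 4 keeps an aryl group on that nitrogen, so no step shown bears on it closely. The expectation is therefore a step of a 1.5-fold lower number from compound 2 to compound 4 (0.16 log units; within the scatter), within or near the scatter. Compound 4 is estimated at 40000 nM, with a range from 10000 nM to 100000 nM.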

Compound 4, half-maximal inhibitory concentration: > 100000 nM
Compound 4 gave a limit, no number; the forecaster's own chance of this, stated with the estimate: 25%; at least 2.5-fold (0.39 log units) between middle value and limit.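

In this assay compound 4 gives > 100000 nM, which is a limit and not a number. The first step shown with an aryl group on both sides of the change on the amide-type nitrogen is an at least 1.7-fold higher number from compound 2 to compound 4 (0.23 log units; that floor lies within the scatter), so its true size remains unknown. On the core shared by compound 2 and compound 4, an aryl group on this nitrogen therefore does not by itself keep the value clear of the limit, which now recurs in this set: the limit of > 100000 nM in this assay, at which 2 of the 4 values shown sit.

On these data alone, it remains open whether the ethoxy group or the loss of the two methyl groups matters more, and how a 4-aminophenyl group or a phenyl ring bearing a carboxylic acid would read on this nitrogen. No pair shown differs only in the hydroxy or methoxy group on the core, so the part played by that group also stays open.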